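The compounds below may be only part of what the source reports. "The series", "measured", "known", "first", "only" and "open" are said of these compounds alone.

Among the measured compounds shown here, in a functional assay on HT-29 cells (Homo sapiens) for antiproliferative activity, read by sulforhodamine B assay, with a stated time of 72 h (a lower number here means a stronger inhibitor, a higher number a weaker inhibitor), compound 1 `CCCCCCCCc1ccc(CCC(CO)(CO)NC(=O)CCCCCCC)c2ccccc12`, which bears a heptyl group on its amide carbonyl carbon, gives 22000 nM, the only true number so far. Compound 2 `CCCCCCCCCCCCCC(=O)NC(CO)(CO)CCc1ccc(CCCCCCCC)c2ccccc12` reads > 80000 nM, and this is a limit of the assay, not a number. For the measured compounds named here, the one measured step is an at least 3.6-fold higher number from compound 1 to compound 2 (0.56 log units; beyond the scatter). It lies beyond the scatter and was made on the same chain. Compound 3 `CCCCCCCCc1ccc(CCC(CO)(CO)NC(=O)c2ccccc2)c2ccccc12` alters that chain differently, with phenyl in place of heptyl on a carbonyl carbon. The measured step extends the chain and does not replace it with a ring, so it bears on this change only loosely. As far as these compounds go, no step beyond the scatter is therefore expected in this assay, and the direction stays open. The expected step is a 1.1-fold higher number from compound 1 to compound 3 (0.06 log units; within the scatter). For compound 3 the estimated value is 25000 nM, with an expected range from 9000 nM to 70000 nM.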

Compound 3, half-maximal inhibitory concentration: 23000 nM
Compound 3: the middle estimate sits 1.1-fold (0.04 log units) above what was measured; the measured number falls inside the stated range.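

In this assay, putting phenyl in place of heptyl on the carbonyl carbon leaves the reading where it was: a 1.0-fold higher number from compound 1 to compound 3 (0.02 log units; within the scatter). At this position, then, a six-membered aromatic ring of carbon only reads the same as the heptyl chain, which the earlier step, a lengthening of that chain, could not show. Compound 2 alone stands at a limit of the assay, not a number, and compound 3 does not join it: the limit of > 80000 nM in this assay, at which 1 of the 3 values shown sits.

As far as these compounds go, whether a shorter chain such as butyl, or a phenyl ring carrying an amine or a carboxylic acid, would move the number beyond the scatter remains open. From the compounds shown here alone, with compound 2 at a limit, how far its longer chain truly lies from compound 1 also stays unknown.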